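Fluoro to hydroxy on compound 2

This account rests on a few compounds, and the source may have more. Where it says the series, first, only, none or still open, it means among the compounds named here.

In a functional assay on MCF7 cells (Homo sapiens) for cytotoxicity, read by MTT assay, with a stated time of 48 h (a lower number here means a stronger inhibitor, a higher number a weaker inhibitor), compound 1 (`COc1cc(N2C(=S)SCC2(O)c2ccc(Cl)cc2Cl)cc(OC)c1OC`) reads 9.6 ug/mL and compound 2 (`COc1cc(-n2c(-c3ccc(F)cc3)csc2=S)cc(OC)c1OC`) reads 38.5 ug/mL as the higher of the two numbers, a gap beyond the scatter. Compound 3 (`COc1cc(-n2c(-c3ccc(O)cc3)csc2=S)cc(OC)c1OC`) is still unmeasured. It carries hydroxy in place of fluoro on an aromatic carbon, para to a large group. Within the data shown here, no measured pair shows this change, so no step beyond the scatter is expected in this assay here. The estimated step (a 1.5-fold lower number from compound 2 to compound 3 (0.19 log units; within the scatter)) leans slightly toward a lower number. The expected value for compound 3 is 25 ug/mL (expected range 9 ug/mL to 70 ug/mL).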

Compound 3, half-maximal inhibitory concentration: 35.1 ug/mL
Estimate against measurement, compound 3: 1.4-fold (0.15 log units) below; low and high end bracket the measured number.
By their numbers in this assay, from the lowest: compound 1; then compounds 3 and 2 (each within the scatter of the next).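

Among these compounds, the exchange of 4-fluorophenyl for 4-hydroxyphenyl in this assay gives a 1.1-fold lower number from compound 2 to compound 3 (0.04 log units; within the scatter) and so provides the first matched pair at this position. At this place, para to a large group, hydroxy brings a hydrogen-bond donor and acceptor where fluoro had none, yet the two numbers stay within the scatter. This read-out therefore does not separate fluoro from hydroxy here.

From the compounds shown here alone, whether an amine, a carboxylic acid or a longer chain at the same place would separate from them remains open. Nothing on hand explains why the two compounds read alike.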